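This account rests on a few compounds, and the source may have more. Where it says the series, first, only, none or still open, it means among the compounds named here.

Working notes on a small set sharing one core. Compound 1 `CSc1[nH]ccc2ncnc1-2` gives < 5% in a functional assay on EL4 cells (Mus musculus) for inhibition, tested at 100 uM; a lower number here means less inhibition, a higher number more inhibition at the concentration tested (going by the name of the read-out); this is a limit of the assay, not a number. Compound 2 `OCCNc1[nH]ccc2ncnc1-2` gives < 5% in this assay, again a limit. Compound 3 `Clc1[nH]ccc2ncnc1-2` gives < 5% in this assay, also a limit. The steps a step that the two limits leave unreadable from compound 1 to compound 2, a step that the two limits leave unreadable from compound 1 to compound 3 and a step that the two limits leave unreadable from compound 2 to compound 3 are all unreadable because of the limit of < 5% in this assay, at which 3 of the 3 values shown sit. Compound 4 `Nc1[nH]ccc2ncnc1-2` differs from compound 3 by amino in place of chloro on an aromatic carbon. Among the compounds with values here, no measured step bears readably on this change; compound 2, which carries a (2-hydroxyethyl)amino group, sits at the same limit as the others, so nothing points to a readable rise. Compound 4 is therefore expected to remain at the limit, with an estimated step that the limit leaves unreadable from compound 3 to compound 4. The estimate for compound 4 in this assay is 3%, range 0% to 12%.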

Compound 4, a percentage reported as inhibition, at one concentration (the size of the read-out at that concentration, not a potency): < 5%
Compound 4: no number, only a limit (the forecaster's own chance of this, stated with the estimate: 85%); the middle value does not contradict the limit.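

No step from compound 4 to compound 1, compound 2 or compound 3 can be read in this assay, because all four sit at the same limit: the limit of < 5% in this assay, at which 4 of the 4 values shown sit.

The compounds shown leave open whether any group on the shared core gives readable inhibition in this assay.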